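A Ring Swap on a Shared Core

The source may report more compounds than this note shows. Statements on the series, on what has been measured and on what is new or still open speak of the compounds shown alone.

In a functional assay on A2780 cells (Homo sapiens) for inhibition (a higher number here means a weaker inhibitor, a lower number a stronger inhibitor), compound 1 `CC(C(=O)Nc1cc(C2CC2)[nH]n1)c1ccc(N2CCNC2=O)cc1` gives 2250 nM and compound 2 `CC(C(=O)Nc1cc(C2CC2)[nH]n1)c1ccc(N2CCCS2(=O)=O)cc1` gives 5240 nM. Compound 3 `CC(C(=O)Nc1cc(C2CC2)[nH]n1)c1ccc(N2CC(=O)NC2=O)cc1` gives 4540 nM, which sits within the scatter of both others, with a 2.0-fold higher number from compound 1 to compound 3 (0.30 log units; within the scatter) and a 1.2-fold lower number from compound 2 to compound 3 (0.06 log units; within the scatter). Compound 4 `CC(C(=O)Nc1cc(C2CC2)[nH]n1)c1ccc(-n2cnnc2O)cc1` changes the same ring again: a group of 6 heavy atoms (2 carbon, 3 nitrogen, 1 oxygen; one five-membered aromatic ring with 3 hetero atoms) in place of a group of 7 heavy atoms (3 carbon, 2 nitrogen, 2 oxygen; one five-membered non-aromatic ring with 2 hetero atoms), on an aromatic carbon. The three measured ring swaps all stayed small, and the largest, a 2.3-fold higher number from compound 1 to compound 2 (0.37 log units; beyond the scatter), is only modest. For the measured compounds named here, none of the measured compounds carries an aromatic ring at this place, so that swap is untested, and in this assay no step beyond the scatter is expected, in either direction. The expected step is a 1.3-fold lower number from compound 3 to compound 4 (0.11 log units; within the scatter). Compound 4 is estimated at 3500 nM, with an expected range from 1500 nM to 8000 nM.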

Compound 4, half-maximal inhibitory concentration: 8390 nM
For compound 4 the middle estimate is 2.4-fold (0.38 log units) below the measured one; measured number outside the range, above it.
By their numbers in this assay, from the lowest: compounds 1, 3, 2 and 4 (each within the scatter of the next, the first and the last beyond it).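

The only aromatic ring shown at this place, in this assay, cannot be told apart from two of the non-aromatic rings, with a 1.8-fold higher number from compound 3 to compound 4 (0.27 log units; within the scatter) and a 1.6-fold higher number from compound 2 to compound 4 (0.20 log units; within the scatter). Against the 2-oxoimidazolidin-1-yl ring it does lose ground, with a 3.7-fold higher number from compound 1 to compound 4 (0.57 log units; beyond the scatter), the largest step at this position so far, though still a modest one. No measurement shown here accounts for that step. Still open, as far as these compounds go, is how a simple amine or a carboxylic acid on this aromatic carbon would compare with these rings.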